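The compounds below may be only part of what the source reports. "The series", "measured", "known", "first", "only" and "open" are said of these compounds alone.

Three compounds share one core and differ only in the aryl group on the urea nitrogen. Compound 1 `CCN(CC)CCCNc1nc(-c2ccc(NC(=O)Nc3ccccc3)cc2)nc2c(Cl)c(Cl)sc12` gives 1780 nM in a functional assay on MDA-MB-231 cells (Homo sapiens) for cytotoxicity, read by MTT assay, with a stated time of 72 h; on this read-out higher numbers stand for weaker inhibition and lower numbers for stronger inhibition. Compound 2 `CCN(CC)CCCNc1nc(-c2ccc(NC(=O)Nc3ccc(F)cc3)cc2)nc2c(Cl)c(Cl)sc12` gives 1630 nM in that assay, and a 1.1-fold lower number from compound 1 to compound 2 (0.04 log units; within the scatter). Compound 3 `CCN(CC)CCCNc1nc(-c2ccc(NC(=O)Nc3ccc(Cl)cc3Cl)cc2)nc2c(Cl)c(Cl)sc12` gives 3940 nM, the highest number of the three: a 2.2-fold higher number from compound 1 to compound 3 (0.35 log units; beyond the scatter), and a 2.4-fold higher number from compound 2 to compound 3 (0.38 log units; beyond the scatter).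

Compound 4 `CCN(CC)CCCNc1nc(-c2ccc(NC(=O)Nc3ccc(C)cc3)cc2)nc2c(Cl)c(Cl)sc12` has not been measured. Relative to compound 3 the change is 4-methylphenyl in place of 2,4-dichlorophenyl on an amide-type nitrogen. Both measured steps that touch this position, from compound 1 to compound 3 and from compound 2 to compound 3, went up by a modest amount when 2,4-dichlorophenyl replaced a phenyl or 4-fluorophenyl. Compound 4 carries a 4-methylphenyl, which on the counted features stands closer to compounds 1 and 2 than to compound 3, so the step is expected to run back down by about the same modest amount, a 2.1-fold lower number from compound 3 to compound 4 (0.32 log units; beyond the scatter). For compound 4 the estimated value in that assay is 1900 nM, within a range from 900 nM to 4000 nM.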

Compound 4, half-maximal inhibitory concentration: 3040 nM
Estimate against measurement, compound 4: 1.6-fold (0.20 log units) below; the measured number falls inside the stated range.
By their numbers in this assay, from the lowest: compounds 2, 1, 4 and 3 (each within the scatter of the next, the first and the last beyond it).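

In this assay the 4-methylphenyl on the amide-type nitrogen cannot be told apart from the 2,4-dichlorophenyl (a 1.3-fold lower number from compound 3 to compound 4 (0.11 log units; within the scatter)), from the 4-fluorophenyl (a 1.9-fold higher number from compound 2 to compound 4 (0.27 log units; within the scatter)) or from the phenyl (a 1.7-fold higher number from compound 1 to compound 4 (0.23 log units; within the scatter)). The earlier compounds shown here showed only a gap beyond the scatter, with compound 3 set off from compound 1 and compound 2; compound 4 now lies within the scatter of both sides, so the four compounds do not fall into two separate groups at this position. No measurement given here offers a reason for any of these steps.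

The compounds shown leave open how a 4-chlorophenyl, carrying one of the two chlorines of compound 3, would compare with the 2,4-dichlorophenyl. They also leave open how an aryl group bearing an amine or a carboxylic acid would read at this nitrogen.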